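This account rests on a few compounds, and the source may have more. Where it says the series, first, only, none or still open, it means among the compounds named here.

Measured so far:
compound 1 `Nc1ncnc2c1c(-c1cc(C3CC3)on1)nn2C1CCCCC1`: 32500 nM
compound 2 `CCc1cc(-c2nn(C(C)C)c3ncnc(N)c23)no1`: 28600 nM
compound 3 `CC(C)n1nc(/C=N/O)c2c(N)ncnc21`: 107000 nM

In an ADME assay on Nthy-ori 3-1 cells (Homo sapiens) for cytotoxicity, read by MTT assay, with a stated time of 10 days (a higher number here means a weaker inhibitor of growth, a lower number a stronger inhibitor of growth), compound 2 gives 28600 nM; compound 1 sits within the usual scatter of that number, whereas compound 3 lies beyond the scatter at a higher number. Within the data shown here, no pair of measured compounds differs in only one place, so no measured step guides the next change. Compound 4 `CC(C)n1nc(-c2cc(-c3ccc(F)cc3)on2)c2c(N)ncnc21` differs from compound 2 by 4-fluorophenyl in place of ethyl on an aromatic carbon. Nothing measured here shows what such a change does in this assay; the expectation is a moderate step towards a lower number, estimated as a 1.9-fold lower number from compound 2 to compound 4 (0.28 log units; within the scatter), with a wide range around it. For compound 4 in this assay the estimate is 15000 nM, expected between 5000 nM and 45000 nM.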

Compound 4, concentration for 50% growth inhibition: 9770 nM
Compound 4: the middle estimate sits 1.5-fold (0.19 log units) above what was measured; the range from low to high includes it.
By their numbers in this assay, from the lowest: compound 4; then compounds 2 and 1 (each within the scatter of the next); then compound 3.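

In this assay, 4-fluorophenyl in place of ethyl on the aromatic carbon next to the ring oxygen gives a 2.9-fold lower number from compound 2 to compound 4 (0.47 log units; beyond the scatter). Among these compounds, this is the only single-place step so far, and it shows that this position accepts the larger aromatic group while the number falls beyond the scatter. Nothing at hand explains the size or direction of this step. As far as these compounds go, whether the step comes from the phenyl ring or from its fluorine stays open, as an unsubstituted phenyl would be needed to separate them. Also open, from the compounds shown here alone, is whether an amine or a carboxylic acid on this carbon would give a similar number.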